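A few compounds are considered here, and "the series" means these few. Any claim that something is new, unique, unknown or untested is made for them only; others in the source may bear on it.

Of the compounds shown here, three sharing one core have been measured in a functional assay on CNE-2 cells (Homo sapiens) for cytotoxicity, read by MTT assay, with a stated time of 72 h; on this read-out lower numbers stand for stronger inhibition and higher numbers for weaker inhibition. Compound 1 `COc1cc2ncnc(NNC(=S)NC(=O)c3ccc(C(F)(F)F)cc3)c2cc1OC` gives 16500 nM, compound 2 `COc1cc2ncnc(NNC(=S)NC(=O)c3ccc(F)cc3)c2cc1OC` gives 16100 nM, and compound 3 `COc1cc2ncnc(NNC(=S)NC(=O)c3cccc(Cl)c3)c2cc1OC` gives 7460 nM. Compound 3 thus stands lowest of the three, with a 2.2-fold lower number from compound 1 to compound 3 (0.34 log units; beyond the scatter) and a 2.2-fold lower number from compound 2 to compound 3 (0.33 log units; beyond the scatter), while a 1.0-fold lower number from compound 1 to compound 2 (0.01 log units; within the scatter).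

Compound 4 `COc1cc2ncnc(NNC(=S)NC(=O)c3ccccc3Cl)c2cc1OC` is the next compound, and its difference from compound 3 is 2-chlorophenyl in place of 3-chlorophenyl on a carbonyl carbon. Within the data shown here, no measured pair shows a chlorine moved from one position of the phenyl ring to another, so the measured steps bear on this change only loosely: the two steps that reach compound 3 each swapped the whole aryl group and gave modest changes, with a 2.2-fold lower number from compound 1 to compound 3 (0.34 log units; beyond the scatter) and a 2.2-fold lower number from compound 2 to compound 3 (0.33 log units; beyond the scatter). On that basis the step from compound 3 to compound 4 in this assay is expected to be a 1.3-fold higher number from compound 3 to compound 4 (0.10 log units; within the scatter), which is within the scatter or close to it. Compound 4 is therefore estimated to give 9500 nM, with a range from 4000 nM to 22000 nM.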

Compound 4, half-maximal inhibitory concentration: 9670 nM
Compound 4: the middle estimate sits 1.0-fold (0.01 log units) below what was measured; low and high end bracket the measured number.
By their numbers in this assay, from the lowest: compounds 3, 4, 2 and 1 (each within the scatter of the next, the first and the last beyond it).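

Moving the chlorine from 3-chlorophenyl to 2-chlorophenyl on a carbonyl carbon keeps the same atoms, and in this assay this gives a 1.3-fold higher number from compound 3 to compound 4 (0.11 log units; within the scatter), so these two chlorine placements cannot be told apart. The 2-chlorophenyl group also cannot be separated from the 4-fluorophenyl or 4-(trifluoromethyl)phenyl groups, with a 1.7-fold lower number from compound 2 to compound 4 (0.22 log units; within the scatter) and a 1.7-fold lower number from compound 1 to compound 4 (0.23 log units; within the scatter), both within the scatter, even though the 3-chlorophenyl group stands beyond the scatter of those same two groups. No supporting measurement is available to explain these small steps.

The compounds shown leave open whether a group of a different kind on this carbonyl carbon, such as a cyclohexyl ring or a phenyl ring carrying an amine or a carboxylic acid, would shift the number by more than the scatter.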